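The source may hold more compounds than are shown below. What is called first, only, known or untested is meant among the compounds shown, and "the series" means these compounds.

Compound 1 `COc1ccc(-c2cnc(Nc3ccc(C#N)cc3)nc2Oc2c(C)cc(C#N)cc2C)cc1` sits at a limit in an ADME assay on MT4 cells (Homo sapiens) for cytotoxicity, read by MTT assay, with a stated time of 5 days (a lower number here means that less compound is tolerated, a higher number that more compound is tolerated), namely > 279000 nM. Compound 2 `Cc1cc(C#N)cc(C)c1Oc1nc(Nc2ccc(C#N)cc2)ncc1-c1ccc(Cl)cc1` gives 72600 nM in this assay. Compound 3 `Cc1cc(C#N)cc(C)c1Oc1nc(Nc2ccc(C#N)cc2)ncc1-c1cncnc1` likewise reaches a limit, > 298000 nM. Compound 3 therefore stands at the top of what the numbers shown can express, with only compound 2 giving a measured figure. Going by the values given here, two steps bear on the change at hand: an at least 3.8-fold lower number from compound 1 to compound 2 (0.58 log units; beyond the scatter) and an at least 4.1-fold higher number from compound 2 to compound 3 (0.61 log units; beyond the scatter), both readable and at least modest. Compound 4 `Cc1cc(C#N)cc(C)c1Oc1nc(Nc2ccc(C#N)cc2)ncc1-c1ccc(F)cc1` differs from compound 3 by 4-fluorophenyl in place of pyrimidin-5-yl on an aromatic carbon. This change largely reverses the step of an at least 4.1-fold higher number from compound 2 to compound 3 (0.61 log units; beyond the scatter), so a lower number is expected in this assay, though a halogen other than chloro may not carry the full distance. Compound 4 is thus estimated at 150000 nM, with a range from 60000 nM to 300000 nM. The expected step is an at least 1.9-fold lower number from compound 3 to compound 4 (0.29 log units; that floor lies within the scatter).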

Compound 4, half-maximal cytotoxic concentration: 42700 nM
Estimate against measurement, compound 4: 3.5-fold (0.55 log units) above, and the stated range ends above it.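

In this assay the change to 4-fluorophenyl gives an at least 6.9-fold lower number from compound 3 to compound 4 (0.84 log units; beyond the scatter) and so a second halogen-bearing phenyl, after the 4-chlorophenyl of compound 2, falls well below the pyrimidin-5-yl. Fluoro and chloro are not told apart here, with a 1.7-fold lower number from compound 2 to compound 4 (0.23 log units; within the scatter) while fluoro does separate from methoxy, with an at least 6.5-fold lower number from compound 1 to compound 4 (0.81 log units; beyond the scatter) as the step. Compound 3 stands at a limit: the limit of > 298000 nM in this assay, at which 1 of the 4 values shown sits. As far as these compounds go, an amine or a carboxylic acid in place of the fluoro remains open. So does pyridin-3-yl in place of the pyrimidin-5-yl.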